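This account rests on a few compounds, and the source may have more. Where it says the series, first, only, none or still open, it means among the compounds named here.

Measured in a functional assay on P388 cells (Mus musculus) for antiproliferative activity; a higher number here means a weaker inhibitor, a lower number a stronger inhibitor:
- compound 1 `N#Cc1ccc(S(=O)(=O)Nc2cccc3c(C#N)c[nH]c23)cc1`: 0.53 ug/mL
- compound 2 `N#Cc1ccc(S(=O)(=O)Nc2cccc3c(Cl)c[nH]c23)cc1`: 1.4 ug/mL

Of these two, compound 2 has the higher number, 1.4 ug/mL, and is therefore the weaker inhibitor in this assay. The next compound to test is compound 3 `CNS(=O)(=O)c1ccc(S(=O)(=O)Nc2cccc3c(Cl)c[nH]c23)cc1`, which keeps the chloro group of compound 2 and carries methylsulfamoyl in place of cyano on an aromatic carbon, para to a large group: methylsulfamoyl in place of cyano on an aromatic carbon.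

For the measured compounds named here, only one measured step bears on this change, and only indirectly: a 2.6-fold higher number from compound 1 to compound 2 (0.42 log units; beyond the scatter). This modest step, beyond the scatter, comes from a different place in the molecule. It shows that a single substitution can move the number in this series, but it says nothing about the direction of this exchange. Going by the values given here, no measured compound varies the cyano group being replaced, so only a small shift is expected in this assay, with low confidence in its direction. The estimated change is a 1.4-fold lower number from compound 2 to compound 3 (0.15 log units; within the scatter). For compound 3 the expected value is 1 ug/mL, with an estimated range of 0.3 ug/mL to 3.5 ug/mL.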

Compound 3, half-maximal inhibitory concentration: 0.9 ug/mL
For compound 3 the middle estimate is 1.1-fold (0.05 log units) above the measured one; the range from low to high includes it.
By their numbers in this assay, from the lowest: compounds 1, 3 and 2 (each within the scatter of the next, the first and the last beyond it).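

In this assay the exchange at this position gives a 1.6-fold lower number from compound 2 to compound 3 (0.19 log units; within the scatter) and so does not separate cyano from methylsulfamoyl on this read-out while the chloro group stays fixed. For the compounds shown here, this is the first measured change at this position, and it shows that a group of 5 heavy atoms with 1 hydrogen-bond donor can replace one of 2 heavy atoms with no donor, on an aromatic carbon para to a large group, without a step beyond the scatter. No supporting measurement is available to explain this result.

From the compounds shown here alone, it remains open whether the same exchange gives a similar step when the cyano group of compound 1 stands in place of the chloro group, which would show whether the two places act independently. Also open, going by these compounds, is how an amine, a carboxylic acid or a longer chain in place of the methyl of methylsulfamoyl would read at this position, and whether any of these would produce a step beyond the scatter.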